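Sulfonyl piperidine series: phenyl to trifluoromethoxy

The source may hold more compounds than are shown below. What is called first, only, known or untested is meant among the compounds shown, and "the series" means these compounds.

Among the compounds with values here, compound 1 `CC1CCN(C2CCN(S(=O)(=O)c3ccc(-c4ccccc4)cc3)CC2)CC1` is the one compound of the series with a measured number: in a functional assay on DLD-1 cells (Homo sapiens) for antiproliferative activity, read by CellTiter-Glo, with a stated time of 72 h (a lower number here means a stronger inhibitor, a higher number a weaker inhibitor), compound 1 gives 258 nM. Compound 2 `CCCC(=O)NC1CCN(S(=O)(=O)c2c(C)cc(C)cc2C)CC1` reaches only a limit of this assay, > 5000 nM. One of the two values shown therefore sits at the limit of > 5000 nM in this assay, at which 1 of the 2 values shown sits. Compound 1 thus stands on the only number shown. Compound 3 `CC1CCN(C2CCN(S(=O)(=O)c3ccc(OC(F)(F)F)cc3)CC2)CC1` is not yet measured in this assay. It differs from compound 1 in one place: trifluoromethoxy in place of phenyl on an aromatic carbon. Within the data shown here, no step between measured compounds with a single change is available, so the size of this change cannot be read from the data. The step expected from compound 1 to compound 3 in this assay is a 1.9-fold higher number from compound 1 to compound 3 (0.29 log units; within the scatter), a modest loss that need not exceed the scatter. Compound 3 is estimated to give about 500 nM in this assay. For compound 3 the expected range runs from 150 nM to 2000 nM.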

Compound 3, half-maximal inhibitory concentration: 16 nM
Compound 3: the middle estimate sits 31-fold (1.49 log units) above what was measured; the measured number lies below the stated range.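

Within the data shown here, exchanging phenyl for trifluoromethoxy on an aromatic carbon, para to a large group, gives in this assay the first single-place step: a 16-fold lower number from compound 1 to compound 3 (1.21 log units; beyond the scatter). The six-membered aromatic ring of the phenyl is therefore not required at this position for activity in this assay on the core of compound 1, and the ring-free trifluoromethoxy is the better of the two groups shown there. No measured property in hand bears on the size of this step.

Going by these compounds, it remains open whether the oxygen or the fluorines matter more, which a methoxy or a trifluoromethyl group at the same position would help to separate. An amine or a carboxylic acid there would show whether the position also accepts a charged group.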